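Trimming the Amide Substituent from Cyclopropyl to Methyl

A few compounds are considered here, and "the series" means these few. Any claim that something is new, unique, unknown or untested is made for them only; others in the source may bear on it.

Compound 1 `C[C@H]1CN(C(=O)c2ccco2)c2cc(-c3ccc(S(C)(=O)=O)cc3)ccc2N1C(=O)C1CC1`: 280 nM
Compound 2 `CCC(=O)N1c2ccc(-c3ccc(S(C)(=O)=O)cc3)cc2N(C(=O)c2ccco2)C[C@@H]1C`: 550 nM

In a functional assay on MV4-11 cells (Homo sapiens) for inhibition, read by luminescence and CellTiter-Glo, with a stated time of 72 h (a lower number here means a stronger inhibitor of growth, a higher number a weaker inhibitor of growth), compound 1 gives 280 nM, and compound 2 gives 550 nM. The step of a 2.0-fold higher number from compound 1 to compound 2 (0.29 log units; within the scatter) lies within the scatter, so the two cannot be told apart. Compound 3 `CC(=O)N1c2ccc(-c3ccc(S(C)(=O)=O)cc3)cc2N(C(=O)c2ccco2)C[C@@H]1C` differs from compound 1 by methyl in place of cyclopropyl on a carbonyl carbon. For the measured compounds named here, the only step that bears on this change is a 2.0-fold higher number from compound 1 to compound 2 (0.29 log units; within the scatter), which was within the scatter; a step of similar size, a 2.1-fold higher number from compound 1 to compound 3 (0.33 log units; beyond the scatter), is therefore expected in this assay. Compound 3 is estimated at 600 nM, with a range from 250 nM to 1500 nM.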

Compound 3, concentration for 50% growth inhibition: 400 nM
Beside the measured number, compound 3's estimate is 1.5-fold (0.18 log units) above it, and the stated range covers the measured number.
By their numbers in this assay, from the lowest: compounds 1, 3 and 2 (each within the scatter of the next).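

Acetyl at this position cannot be separated from either neighbour in this assay: the data show a 1.4-fold higher number from compound 1 to compound 3 (0.15 log units; within the scatter) and a 1.4-fold lower number from compound 2 to compound 3 (0.14 log units; within the scatter). Across cyclopropyl, ethyl and methyl on this carbonyl carbon, removing the three-membered ring or shortening the chain gives no step beyond the scatter. Nothing at hand offers an explanation for this. The compounds shown leave open whether a longer chain, an amine or a carboxylic acid carried on this carbonyl carbon would give a step beyond the scatter.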